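The source may hold more compounds than are shown below. What is called first, only, known or untested is meant among the compounds shown, and "the series" means these compounds.

Measured so far in an assay on HEK293 cells for displacement of a labelled ligand from 5-hydroxytryptamine receptor 7 (Homo sapiens); on this read-out lower numbers stand for stronger inhibition and higher numbers for weaker inhibition: compound 1 `O=C1c2ccccc2S(=O)(=O)N1CCCCCN1CCN(c2ccccc2)CC1` gives 148 nM; compound 2 `O=C1c2ccccc2S(=O)(=O)N1CCCCCN1CCN(c2ccccn2)CC1` gives 179 nM; compound 3 `O=C1c2ccccc2S(=O)(=O)N1CCCCCN1CCN(c2cccc(C(F)(F)F)c2)CC1` gives 35 nM.

Compound 3 holds the lowest number of the three, seen in the steps of a 4.2-fold lower number from compound 1 to compound 3 (0.63 log units; beyond the scatter) and a 5.1-fold lower number from compound 2 to compound 3 (0.71 log units; beyond the scatter), while the step of a 1.2-fold higher number from compound 1 to compound 2 (0.08 log units; within the scatter) lies within the scatter. Compound 4 `O=C1c2ccccc2S(=O)(=O)N1CCCCCN1CCN(c2cccc3ccccc23)CC1` differs from compound 3 by naphthalen-1-yl in place of 3-(trifluoromethyl)phenyl on an amine nitrogen in a ring. Within the data shown here, no measured step touches naphthalen-1-yl, so the bearing steps are only those just named, which show that the group on the ring nitrogen moves this assay by modest amounts. For compound 4 a step of a 1.3-fold higher number from compound 3 to compound 4 (0.11 log units; within the scatter) is expected, close to the scatter. Compound 4 is therefore estimated at 45 nM, in a range from 12 nM to 170 nM.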

Compound 4, inhibition constant: 36 nM
Beside the measured number, compound 4's estimate is 1.3-fold (0.10 log units) above it; low and high end bracket the measured number.
By their numbers in this assay, from the lowest: compounds 3 and 4 (each within the scatter of the next); then compounds 1 and 2 (each within the scatter of the next).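

In this assay, naphthalen-1-yl on the amine nitrogen in a ring stands level with 3-(trifluoromethyl)phenyl, with a 1.0-fold higher number from compound 3 to compound 4 (0.01 log units; within the scatter). The other two steps, a 4.1-fold lower number from compound 1 to compound 4 (0.61 log units; beyond the scatter) and a 5.0-fold lower number from compound 2 to compound 4 (0.70 log units; beyond the scatter), show that a group with 2 six-membered aromatic rings of carbon only and no fluorine also separates from phenyl and pyridin-2-yl at this position. Nothing available explains why these two different groups give matching numbers. Still open, as far as these compounds go, is whether naphthalen-2-yl or a methoxy-substituted phenyl would fall at the same level. Also open, from the compounds shown here alone, is how a shorter chain would alter these numbers.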